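The source may hold more compounds than are shown below. What is called first, only, known or untested is meant among the compounds shown, and "the series" means these compounds.

In an ADME assay for permeability (a lower number here means that the compound crosses the layer more slowly, a higher number that the compound crosses the layer faster), compound 1 (`CNC(=O)c1cc(C(=O)N[C@H]2[C@@H]3COC[C@@H]32)c([C@@H](C)c2ccccc2)o1`) gives 200 nm/s, while compound 2 (`CNC(=O)c1cc(C(=O)N[C@H]2CC[C@H](O)CC2)c([C@@H](C)c2ccccc2Cl)o1`) gives 78 nm/s, the lower of the two numbers, by a gap beyond the usual scatter. Compound 3 (`CNC(=O)c1cc(C(=O)N[C@H]2CC[C@H](O)CC2)c([C@@H](C)c2ccccc2)o1`) differs from compound 2 in one place: hydrogen in place of chloro on an aromatic carbon, with hydrogen in place of chloro on an aromatic carbon, ortho to a large group. Going by the values given here, no measured pair shows this change. In this assay, the expected step is a 1.1-fold higher number from compound 2 to compound 3 (0.04 log units; within the scatter), which would be none beyond the scatter. For compound 3 the estimated value is 85 nm/s, with an expected range of 40 nm/s to 170 nm/s.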

Compound 3, apparent permeability: 42 nm/s
Beside the measured number, compound 3's estimate is 2.0-fold (0.31 log units) above it, and the stated range covers the measured number.
By their numbers in this assay, from the lowest: compounds 3 and 2 (each within the scatter of the next); then compound 1.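

In this assay, replacing chloro with hydrogen on the aromatic carbon ortho to a large group gives a 1.9-fold lower number from compound 2 to compound 3 (0.27 log units; within the scatter), so this change at this position shows no effect beyond the scatter. The change on the amide-type nitrogen, with the group of 7 heavy atoms in place of the group of 6, gives the larger 4.8-fold lower number from compound 1 to compound 3 (0.68 log units; beyond the scatter). Nothing at hand explains either step. On these data alone, it remains open how fluoro, methoxy or trifluoromethyl would read at the place of the chloro. As far as these compounds go, it also remains open whether the step on the amide-type nitrogen holds with chloro present.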